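Moving the methyl around the benzyl thioether

The source may report more compounds than this note shows. Statements on the series, on what has been measured and on what is new or still open speak of the compounds shown alone.

Three compounds sharing one core were measured in a functional assay on SMMC-7721 cells (Homo sapiens) for antiproliferative activity, read by CCK-8 assay, with a stated time of 48 h; a higher number here means a weaker inhibitor, a lower number a stronger inhibitor. Compound 1 `CCCCSc1n[nH]c(-n2[se]c3ccccc3c2=O)n1` gives 16800 nM. Compound 2 `CCCCCCSc1n[nH]c(-n2[se]c3ccccc3c2=O)n1` gives 22400 nM. Compound 3 `Cc1ccc(CSc2n[nH]c(-n3[se]c4ccccc4c3=O)n2)cc1` gives > 50000 nM, which is a limit of the assay and not a number.

The two alkyl thioethers sit close together: a 1.3-fold higher number from compound 1 to compound 2 (0.12 log units; within the scatter). Putting the benzyl group in place of either chain raises the number: an at least 2.9-fold higher number from compound 1 to compound 3 (0.47 log units; beyond the scatter) and an at least 2.2-fold higher number from compound 2 to compound 3 (0.34 log units; beyond the scatter). Compound 3 thus stands at the upper end of the values shown, and for it only the limit of > 50000 nM in this assay, at which 1 of the 3 values shown sits, is known.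

Compound 4 `Cc1cccc(CSc2n[nH]c(-n3[se]c4ccccc4c3=O)n2)c1` differs from compound 3 by 3-methylphenyl in place of 4-methylphenyl on a saturated chain carbon bound to a sulfur. For the measured compounds named here, no measured step moves a methyl from one ring position to another, so the steps that bear on compound 4 are the two that brought the benzyl group in, an at least 2.9-fold higher number from compound 1 to compound 3 (0.47 log units; beyond the scatter) and an at least 2.2-fold higher number from compound 2 to compound 3 (0.34 log units; beyond the scatter), both at least modest and both ending at the limit. The isomeric benzyl group is therefore expected to stay near that limit, with a number no higher from compound 3 to compound 4 (the limit leaves the size open) as the expected step, not beyond the scatter. Compound 4 is estimated at 50000 nM, with a range from 22000 nM to 120000 nM, and a limit rather than a number is again the likelier report.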

Compound 4, half-maximal inhibitory concentration: 9040 nM
Estimate against measurement, compound 4: 5.5-fold (0.74 log units) above; measured number below the stated range.
By their numbers in this assay, from the lowest: compounds 4, 1 and 2 (each within the scatter of the next, the first and the last beyond it). At a limit, above all of these: compound 3.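

Moving the methyl is enough on its own to change the result in this assay: with the same atoms joined differently, 3-methylphenyl in place of 4-methylphenyl on a saturated chain carbon bound to a sulfur gives an at least 5.5-fold lower number from compound 3 to compound 4 (0.74 log units; beyond the scatter). The earlier compounds shown here suggested that an aryl group at this place raised the number, but that holds only for the 4-methylbenzyl group, as the 3-methylbenzyl group gives a 2.5-fold lower number from compound 2 to compound 4 (0.39 log units; beyond the scatter) against the pentyl-bearing chain and a 1.9-fold lower number from compound 1 to compound 4 (0.27 log units; within the scatter) against the propyl-bearing chain, the second of these being within the scatter. The value for compound 3 is a limit and not a number, so the size of the step from it remains open on one side: the limit of > 50000 nM in this assay, at which 1 of the 4 values shown sits.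

The compounds shown leave open what an unsubstituted benzyl group would give at this place, and whether a chlorine or a methoxy group in place of the methyl would follow the same difference between the 4-substituted and 3-substituted rings. On these data alone, they also give no reason for the difference between the two isomers, and whether it extends beyond this assay remains unknown.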